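The source may report more compounds than this note shows. Statements on the series, on what has been measured and on what is new or still open speak of the compounds shown alone.

In a functional assay on the whole organism with Rattus norvegicus as the target (on this read-out higher numbers stand for an effect only at larger amounts of compound and lower numbers for an effect already at smaller amounts), compound 1 `Cc1ccccc1OCC(O)CNCC(=O)Nc1ccc(C2=NNC(=O)CC2C)cc1` gives 2.7 umol/kg.
In this assay compound 2 `COc1ccccc1OCC(O)CNCC(=O)Nc1ccc(C2=NNC(=O)CC2C)cc1` gives 3 umol/kg.
In this assay compound 3 `Cc1ccccc1OCC(O)CNCCC(=O)Nc1ccc(C2=NNC(=O)CC2)cc1` gives 6 umol/kg.

Compound 2 differs from compound 1 in a single place, (methoxy in place of methyl on an aromatic carbon), and this change gave a 1.1-fold higher number from compound 1 to compound 2 (0.05 log units; within the scatter). Compound 4 `COc1ccccc1OCC(O)CNCCC(=O)Nc1ccc(C2=NNC(=O)CC2)cc1` has not yet been measured; it differs from compound 3 by the same change, (methoxy in place of methyl on an aromatic carbon), at a place described in the same words. The difference between the two cores, that of compound 1 and that of compound 3, is not broken down here. Among the compounds with values here, for compound 4 the step from compound 3 is expected to be a 1.1-fold higher number from compound 3 to compound 4 (0.03 log units; within the scatter), a size that rests on the single earlier example, because the same change gave a 1.1-fold higher number from compound 1 to compound 2 (0.05 log units; within the scatter). Compound 4 is therefore estimated to give about 6.5 umol/kg, expected to fall between 3.2 umol/kg and 13 umol/kg.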

Compound 4, dose for half-maximal effect: 4.3 umol/kg
Compound 4: the middle estimate sits 1.5-fold (0.18 log units) above what was measured; the measured number falls inside the stated range.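

In this assay, methoxy in place of methyl on the aromatic carbon gives a small step on the core of compound 3 (a 1.4-fold lower number from compound 3 to compound 4 (0.14 log units; within the scatter)), and the two steps do not differ: the same change on two cores in this assay, a 1.1-fold higher number (0.05 log units; within the scatter) from compound 1 to compound 2 and a 1.4-fold lower number (0.14 log units; within the scatter) from compound 3 to compound 4, 1.6-fold (0.19 log units) apart, within the scatter of two such steps. In these two pairs, then, the change carries from one core to the other without a step that stands out from the scatter. This does not show that a small real effect is absent, or that the change would behave the same way on any other core in the series.

The compounds shown leave open what other groups on this aromatic carbon would give, such as ethoxy, a longer chain or an amine. They also leave open whether any such group would move the number beyond the scatter.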